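A Tertiary Alcohol in Place of the Acetyl Group

This account rests on a few compounds, and the source may have more. Where it says the series, first, only, none or still open, it means among the compounds named here.

Three measured compounds share one core and differ only in the group on one aromatic carbon. Compound 1 `CC(=O)NCc1cccc(Cn2nc(NS(=O)(=O)c3ccc(Cl)s3)c3c(C#N)cccc32)c1` carries a cyano group, and in a functional assay on CHO cells for antagonist activity at C-C chemokine receptor type 4 (Homo sapiens), read by GTPgammaS binding (a higher number here means a weaker inhibitor, a lower number a stronger inhibitor), compound 1 gives 316 nM. Compound 2 `CC(=O)NCc1cccc(Cn2nc(NS(=O)(=O)c3ccc(Cl)s3)c3c(CO)cccc32)c1` carries a hydroxymethyl group and gives 6.31 nM. Compound 3 `CC(=O)NCc1cccc(Cn2nc(NS(=O)(=O)c3ccc(Cl)s3)c3c(C(C)=O)cccc32)c1` carries an acetyl group and gives 100 nM. Compound 3 thus stands second highest of the three numbers: a 3.2-fold lower number from compound 1 to compound 3 (0.50 log units; beyond the scatter), whereas a 16-fold higher number from compound 2 to compound 3 (1.20 log units; beyond the scatter).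

Compound 4 `CC(=O)NCc1cccc(Cn2nc(NS(=O)(=O)c3ccc(Cl)s3)c3c(C(C)(C)O)cccc32)c1` is not yet measured. Its change from compound 3 is 1-hydroxy-1-methylethyl in place of acetyl on an aromatic carbon. The incoming group, like the hydroxymethyl of compound 2, brings one hydrogen-bond donor and one acceptor, which the acetyl lacks. The step that bears on this most directly is a 16-fold higher number from compound 2 to compound 3 (1.20 log units; beyond the scatter), read in the reverse direction; a 50-fold lower number from compound 1 to compound 2 (1.70 log units; beyond the scatter) also shows how much the hydroxymethyl was favored. Because compound 4 is not compound 2, the full reversal is uncertain, so a large but partial improvement is expected. Compound 4 is estimated at 20 nM, within 5 nM to 80 nM. The expected change is a 5.0-fold lower number from compound 3 to compound 4 (0.70 log units; beyond the scatter).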

Compound 4, half-maximal inhibitory concentration: 100 nM
Estimate against measurement, compound 4: 5.0-fold (0.70 log units) below; the measured number lies above the stated range.
By their numbers in this assay, from the lowest: compound 2; then compounds 3 and 4 (each within the scatter of the next); then compound 1.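

In this assay the swap of acetyl for 1-hydroxy-1-methylethyl gives no change at the digits printed from compound 3 to compound 4 (within the scatter) even though the incoming group brings a hydrogen-bond donor that acetyl lacks, so a donor on this aromatic carbon is not enough on its own. Hydroxymethyl and 1-hydroxy-1-methylethyl both carry that donor, yet the numbers show a 16-fold higher number from compound 2 to compound 4 (1.20 log units; beyond the scatter) as a large loss, so the benefit seen with compound 2 does not extend to both alcohols shown here. Against the nitrile, the numbers show a 3.2-fold lower number from compound 1 to compound 4 (0.50 log units; beyond the scatter) as a modest gain, so compound 4 keeps the edge over compound 1 that compound 3 also has.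

Nothing available here gives a reason for these differences. On these data alone, it stays open whether a 1-hydroxyethyl group, an aminomethyl group or a carboxylic acid on this carbon would come closer to compound 2 or to compound 3.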